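A few compounds are considered here, and "the series" means these few. Any claim that something is new, unique, unknown or untested is made for them only; others in the source may bear on it.

Measured so far:

compound 1, `Cc1cccc(C(=O)Nc2cccc(/C=C/C(=O)c3nc4ccccc4[nH]3)c2)c1`: 5590 nM
compound 2, `Cc1ccc(C(=O)Nc2cccc(/C=C/C(=O)c3nc4ccccc4[nH]3)c2)cc1`: 9690 nM
compound 3, `O=C(Nc1cccc(/C=C/C(=O)c2nc3ccccc3[nH]2)c1)c1cccc(C(F)(F)F)c1`: 21500 nM

All three numbers come from a functional assay on MCF7 cells (Homo sapiens) for antiproliferative activity, read by MTT assay, with a stated time of 48 h; a lower number here means a stronger inhibitor, a higher number a weaker inhibitor. Compound 2 holds the second highest number of the three; the step of a 1.7-fold higher number from compound 1 to compound 2 (0.24 log units; within the scatter) stays within the scatter, while a 2.2-fold higher number from compound 2 to compound 3 (0.35 log units; beyond the scatter) lies beyond it, as does a 3.8-fold higher number from compound 1 to compound 3 (0.59 log units; beyond the scatter).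

Compound 4 is `Cc1cccc(S(=O)(=O)Nc2cccc(/C=C/C(=O)c3nc4ccccc4[nH]3)c2)c1`. Relative to compound 2 the change is (3-methylphenyl)sulfonyl in place of (4-methylphenyl)carbonyl on a nitrogen on an aromatic ring. Only the move of the methyl group has a measured parallel, a 1.7-fold higher number from compound 1 to compound 2 (0.24 log units; within the scatter), which was within the scatter; the swap of a carbonyl for a sulfonyl has no parallel among the measured compounds. The step of a 1.5-fold lower number from compound 2 to compound 4 (0.17 log units; within the scatter) is therefore expected to be small, with little confidence in its direction. Compound 4 is estimated at 6500 nM, in a range of 2000 nM to 21000 nM.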

Compound 4, half-maximal inhibitory concentration: 886 nM
The estimate for compound 4 lay 7.3-fold (0.87 log units) above the measured number, and the stated range ends above it.
By their numbers in this assay, from the lowest: compound 4; then compounds 1 and 2 (each within the scatter of the next); then compound 3.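

Among the earlier compounds, only the group on the aromatic ring changed, so this is the first look at the link on the nitrogen itself. In this assay, replacing (3-methylphenyl)carbonyl with (3-methylphenyl)sulfonyl gives a 6.3-fold lower number from compound 1 to compound 4 (0.80 log units; beyond the scatter), while an 11-fold lower number from compound 2 to compound 4 (1.04 log units; beyond the scatter) also moves the methyl group. No measurement here explains this gain.

As far as these compounds go, it remains open whether a sulfonyl link gives a similar gain with 4-methylphenyl or 3-(trifluoromethyl)phenyl, and how a urea link would compare.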